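This account rests on a few compounds, and the source may have more. Where it says the series, first, only, none or still open, it means among the compounds named here.

Compound 2, with the structure `COc1nc(-c2ccccc2)cc(-c2ccc(Cl)cc2)c1C#N`, gives 252 nM in an assay on isolated protein for inhibition of sulfide:quinone oxidoreductase, mitochondrial (Homo sapiens) (a higher number here means a weaker inhibitor, a lower number a stronger inhibitor), the higher of the two numbers measured. Compound 1, with the structure `COc1cccc(-c2cc(-c3ccc(F)cc3)c(C#N)c(OC)n2)c1`, gives 108 nM in this assay, a gap beyond the scatter. Compound 3, with the structure `COc1nc(-c2ccccc2)cc(-c2ccccc2)c1C#N`, differs from compound 2 by hydrogen in place of chloro on an aromatic carbon. Within the data shown here, no measured pair shows this exact change, so the expectation rests on the change alone. A modest step toward a higher number is expected, a 1.8-fold higher number from compound 2 to compound 3 (0.25 log units; within the scatter). Compound 3 is therefore estimated at 450 nM, expected to fall between 150 nM and 1300 nM.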

Compound 3, half-maximal inhibitory concentration: 53 nM
Compound 3: middle estimate off by 8.5-fold (0.93 log units), on the high side; the whole stated range lies above it.
By their numbers in this assay, from the lowest: compound 3; then compound 1; then compound 2.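

In this assay, replacing chloro with hydrogen gives a 4.8-fold lower number from compound 2 to compound 3 (0.68 log units; beyond the scatter) and turns the 4-chlorophenyl into a plain phenyl, a step beyond the scatter. At this carbon, para to a large group, the chloro group therefore goes with a weaker inhibitor on this core, and the unsubstituted ring gives the better number. No measurement shown here accounts for this step. Going by these compounds, whether a methyl group or an amine at the same carbon would land nearer compound 3 or compound 2 stays open, as does whether this change behaves alike on other cores.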